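From a methyl to a methoxy on the aryl ring

The source may report more compounds than this note shows. Statements on the series, on what has been measured and on what is new or still open speak of the compounds shown alone.

Measured so far in (a functional assay on HCT-15 cells (Homo sapiens) for antiproliferative activity, read by MTT assay, with a stated time of 72 h; a lower number here means a stronger inhibitor, a higher number a weaker inhibitor)
Compound 1 (`CCCCCn1ccnc1-c1cc(OC)c(OC)c(OC)c1`) gives (> 100000 nM)
Compound 2 (`COc1ccc(-n2ccnc2-c2cc(OC)c(OC)c(OC)c2)cc1[N+](=O)[O-]`) gives (1000 nM)
Compound 3 (`COc1cc(-c2nccn2-c2ccc(C)cc2)cc(OC)c1OC`) gives (800 nM)

The entry for compound 1 (> 100000 nM) is a limit and not a number. Compound 3 (800 nM) lies within the usual scatter of compound 2 (1000 nM), so these two cannot be ranked.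

Compound 4 (`COc1ccc(-n2ccnc2-c2cc(OC)c(OC)c(OC)c2)cc1`) differs from compound 3 in one place (methoxy in place of methyl on an aromatic carbon): methoxy in place of methyl on an aromatic carbon, turning 4-methylphenyl into 4-methoxyphenyl.

Among the compounds with values here, only one measured step is available (an at least 120-fold lower number from compound 1 to compound 3 (2.09 log units; beyond the scatter)). It was large, but it swapped pentyl for a whole aromatic ring, a far bigger change than this one. Compound 2 (1000 nM) carries methoxy on its ring together with a nitro group, and its number stays within the scatter of compound 3.

In this assay only a small shift is therefore expected, slightly downward and not clearly beyond the scatter (a 1.6-fold lower number from compound 3 to compound 4 (0.20 log units; within the scatter)). Compound 4 is estimated at (500 nM), with an expected range from (60 nM) to (3000 nM).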

Compound 4, half-maximal inhibitory concentration: 1300 nM
Compound 4: the middle estimate sits 2.6-fold (0.41 log units) below what was measured; low and high end bracket the measured number.
By their numbers in this assay, from the lowest: compounds 3, 2 and 4 (each within the scatter of the next). At a limit, above all of these: compound 1.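

In this assay, methoxy in place of methyl on the aromatic ring gives a 1.6-fold higher number from compound 3 to compound 4 (0.21 log units; within the scatter), so this position accepts a group with one more heavy atom and a hydrogen-bond acceptor without a change that can be read. Replacing the nitro group with hydrogen gives a 1.3-fold higher number from compound 2 to compound 4 (0.11 log units; within the scatter), which is also within the scatter, so neither of these ring changes separates the compounds. The large difference remains the one between pentyl and an aromatic ring, seen again in an at least 76-fold lower number from compound 1 to compound 4 (1.88 log units; beyond the scatter), a step that rests on a limit and not on a number: the limit of > 100000 nM in this assay, at which 1 of the 4 values shown sits.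

Still open, from the compounds shown here alone, is whether an amine or a carboxylic acid at this position would move the number beyond the scatter. Going by these compounds, it is also open whether a benzyl group on the nitrogen would behave like pentyl or like the aromatic rings.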